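This account rests on a few compounds, and the source may have more. Where it says the series, first, only, none or still open, it means among the compounds named here.

Working notes on the series.

Among the measured compounds shown here, compound 1 `CCNCC1CCN(c2nc3c(cc2F)c(=O)c(C(=O)O)cn3C2CC2)C1` is one of two compounds measured so far in a functional assay on V79 cells (Cricetulus griseus) for cytotoxicity, read by colony formation (on this read-out lower numbers stand for stronger inhibition and higher numbers for weaker inhibition), where compound 1 gives 160 ug/mL, the highest of the two numbers. Compound 2 `COc1c(N2CCC(C)(CN)C2)c(F)cc2c(=O)c(C(=O)O)cn(C3CC3)c12` gives 38 ug/mL in this assay, a lower number than compound 1 by a gap that lies beyond the usual scatter.

The next compound to be measured is compound 3 `CC1(CN)CCN(c2nc3c(cc2F)c(=O)c(C(=O)O)cn3C2CC2)C1`. It differs from compound 1 in one place: 3-(aminomethyl)-3-methylpyrrolidin-1-yl in place of 3-((ethylamino)methyl)pyrrolidin-1-yl on an aromatic carbon. For the measured compounds named here, no step between measured compounds with this kind of change is available, so the direction and size of the step must be estimated from the two numbers at hand. A downward step is expected, toward lower numbers, of a size that may lie beyond the scatter but is uncertain; the step from a 2.0-fold lower number from compound 1 to compound 3 (0.30 log units; within the scatter) is the expected one. Compound 3 is therefore estimated at 80 ug/mL in this assay, with a range from 35 ug/mL to 180 ug/mL.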

Compound 3, half-maximal inhibitory concentration: 25 ug/mL
Compound 3: middle estimate off by 3.2-fold (0.51 log units), on the high side; the whole stated range lies above it.
By their numbers in this assay, from the lowest: compounds 3 and 2 (each within the scatter of the next); then compound 1.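

In this assay, among the compounds shown here, the change to 3-(aminomethyl)-3-methylpyrrolidin-1-yl on this aromatic carbon gives a 6.4-fold lower number from compound 1 to compound 3 (0.81 log units; beyond the scatter) on the same core, the first step at this position that can be read with everything else held constant. The number at this position therefore responds to the side chain alone, with the pyrrolidine ring kept and only its substituents altered. No measurement at hand bears on why the step occurs.

From the compounds shown here alone, the change removes the ethyl group from the side-chain amine and adds a methyl group to the ring in a single step, so the share of each remains open; a plain 3-(aminomethyl)pyrrolidin-1-yl group would separate the two. Going by these compounds, whether a piperazine ring at this position follows the same direction also remains open.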